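Fluoro in place of hydrogen on compound 1

The source may hold more compounds than are shown below. What is called first, only, known or untested is meant among the compounds shown, and "the series" means these compounds.

Compound 1 `c1ccc(-c2ccc(-c3ccc(-c4nc5ccccc5[nH]4)cc3)cc2)cc1`: 41200 nM
Compound 2 `COc1cc(-c2ccc(-c3ccc(-c4nc5cc(C)ccc5[nH]4)cc3)cc2)cc(OC)c1OC`: < 100 nM (a limit)

For the measured compounds named here, in a functional assay on A549 cells (Homo sapiens) for inhibition, read by sulforhodamine B assay (a higher number here means a weaker inhibitor of growth, a lower number a stronger inhibitor of growth), compound 1 gives 41200 nM, the only exact number so far. Compound 2 gives < 100 nM, which is a limit and not a number. Compound 1 therefore stands far on the weaker side of compound 2 in this assay.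

Compound 3 `Fc1ccc(-c2ccc(-c3ccc(-c4nc5ccccc5[nH]4)cc3)cc2)cc1` carries fluoro in place of hydrogen on an aromatic carbon of compound 1, para to a large group: fluoro in place of hydrogen on an aromatic carbon. Going by the values given here, no measured pair isolates this change, so the expectation is only a rough one. The expected 1.2-fold lower number from compound 1 to compound 3 (0.07 log units; within the scatter) is no larger than the scatter in this assay, with no clear direction. For compound 3 the expected value is 35000 nM, with an estimated range of 12000 nM to 90000 nM.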

Compound 3, concentration for 50% growth inhibition: 33200 nM
The estimate for compound 3 lay 1.1-fold (0.02 log units) above the measured number, and the stated range covers the measured number.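

In this assay, fluoro in place of hydrogen on an aromatic carbon, para to a large group, gives a 1.2-fold lower number from compound 1 to compound 3 (0.09 log units; within the scatter), so this step does not separate compound 3 from compound 1. This is the only pair shown that differs in one place, and it shows that phenyl to 4-fluorophenyl does not by itself bring the series towards the value of compound 2. Nothing shown gives a cause for this result.

Compound 2 differs from compound 1 in more than one place. On these data alone, the value of compound 2, < 100 nM, is a limit, so which of its differences matters stays open. As far as these compounds go, what an amine or a carboxylic acid would do at this same position in this assay also stays open.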